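Shortening the dialkylamino chain on a quinoline-type antagonist

A few compounds are considered here, and "the series" means these few. Any claim that something is new, unique, unknown or untested is made for them only; others in the source may bear on it.

Compound 1 `Cc1cc(C)c(Nc2nc3cccc(N(CC4CC4)C4CCOCC4)c3cc2C)c(C)c1` and compound 2 `CCCN(CCC)c1cccc2nc(Oc3c(OC)cc(COC)cc3OC)c(C)cc12` were both tested in a functional assay on HEK293 cells for antagonist activity at corticotropin-releasing factor receptor 1 (Homo sapiens), read by cAMP accumulation and immunoassay, with a stated time of 30 min; a lower number here means a stronger inhibitor, a higher number a weaker inhibitor. In this assay compound 1 gives 255 nM, and compound 2 gives 163 nM. The gap between these two numbers lies within the usual scatter of repeated measurements, so the two compounds cannot be separated from each other on the present data, and neither can be called more potent than the other.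

Compound 3 `CCN(CC)c1cccc2nc(Oc3c(OC)cc(COC)cc3OC)c(C)cc12` has not yet been measured. It differs from compound 2 in a single place: diethylamino in place of dipropylamino on an aromatic carbon. Among the compounds with values here, no pair of measured compounds differing in one place is available here, so the size of this step has to be judged without a direct precedent. The expectation is that the step from compound 2 to compound 3 in this assay amounts to a 1.8-fold higher number from compound 2 to compound 3 (0.26 log units; within the scatter), a modest move toward a weaker inhibitor that may or may not clear the scatter. On that basis compound 3 is estimated at 300 nM in this assay, with a range from 100 nM to 1000 nM.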

Compound 3, half-maximal inhibitory concentration: 167 nM
Compound 3: middle estimate off by 1.8-fold (0.25 log units), on the high side; low and high end bracket the measured number.
By their numbers in this assay, from the lowest: compounds 2, 3 and 1 (each within the scatter of the next).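

In this assay, within the data shown here, exchanging dipropylamino for diethylamino on the aromatic carbon of the shared core amounts to a 1.0-fold higher number from compound 2 to compound 3 (0.01 log units; within the scatter), and this is the first direct reading of a single change at this position. Across this pair, the amino group goes from 7 heavy atoms to 5 with no ring, donor, acceptor or charge altered, and the two compounds cannot be told apart by their numbers, so this trimming of both alkyl chains leaves no detectable mark on the read-out. Nothing available accounts for this result, and the data offer no explanation of why the two chains read alike.

This single pair does not show how far the insensitivity extends, since it covers only the span from dipropylamino to diethylamino. Going by these compounds, whether this assay would also fail to separate a smaller dimethylamino group, a longer dibutylamino group, or a ring amine such as pyrrolidine or morpholine at this position remains open, as does whether two unequal alkyl groups on the nitrogen would read the same way on this core.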